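A few compounds are considered here, and "the series" means these few. Any claim that something is new, unique, unknown or untested is made for them only; others in the source may bear on it.

Compound 1 `CN(C(=O)C(C)(C)C)c1ccc2[nH]c(-c3n[nH]c4ccccc34)cc2n1` is one of three closely related compounds measured in a functional assay on KB cells (Homo sapiens) for antiproliferative activity, read by MTT assay, with a stated time of 72 h; a higher number here means a weaker inhibitor, a lower number a stronger inhibitor. In this assay compound 1 gives 8390 nM, compound 2 `COc1cccc(C(=O)N(C)c2ccc3[nH]c(-c4n[nH]c5ccccc45)cc3n2)c1` gives 9010 nM, and compound 3 `CN(c1ccc2[nH]c(-c3n[nH]c4ccccc34)cc2n1)S(=O)(=O)c1ccccc1` gives 2400 nM. Compound 1 thus stands second highest of the three numbers: the step of a 1.1-fold higher number from compound 1 to compound 2 (0.03 log units; within the scatter) lies within the scatter, while a 3.5-fold lower number from compound 1 to compound 3 (0.54 log units; beyond the scatter) is a modest gain. Compound 4 `Cc1ccc(S(=O)(=O)N(C)c2ccc3[nH]c(-c4n[nH]c5ccccc45)cc3n2)cc1` differs from compound 1 in one place: (4-methylphenyl)sulfonyl in place of (tert-butyl)carbonyl on a nitrogen on an aromatic ring. The two measured steps that bear on this, a 3.5-fold lower number from compound 1 to compound 3 (0.54 log units; beyond the scatter) and a 3.8-fold lower number from compound 2 to compound 3 (0.57 log units; beyond the scatter), both replace a carbonyl group with a sulfonyl group on a nitrogen on an aromatic ring, and both lower the number modestly. A step of similar size, a 3.8-fold lower number from compound 1 to compound 4 (0.58 log units; beyond the scatter), is therefore expected, and compound 4 is estimated at 2200 nM, with a range from 800 nM to 6000 nM.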

Compound 4, half-maximal inhibitory concentration: 9500 nM
For compound 4 the middle estimate is 4.3-fold (0.64 log units) below the measured one; measured number above the stated range.
By their numbers in this assay, from the lowest: compound 3; then compounds 1, 2 and 4 (each within the scatter of the next).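

A sulfonyl group on this nitrogen does not by itself lower the number: (4-methylphenyl)sulfonyl in place of (tert-butyl)carbonyl gives only a small step (a 1.1-fold higher number from compound 1 to compound 4 (0.05 log units; within the scatter)), and the comparison with the (3-methoxyphenyl)carbonyl group is similar (a 1.1-fold higher number from compound 2 to compound 4 (0.02 log units; within the scatter)). A single methyl in place of hydrogen on the aromatic ring of the sulfonyl group cancels the gain (a 4.0-fold higher number from compound 3 to compound 4 (0.60 log units; beyond the scatter)), leaving compound 3 alone among the four. No measurement here accounts for this effect of the methyl.

Still open, going by these compounds, is whether a fluorine or an amine at that ring carbon would act like hydrogen or like methyl. Also open, on these data alone, is how a simple methylsulfonyl group on this nitrogen would compare.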